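The source may hold more compounds than are shown below. What is called first, only, known or untested is meant among the compounds shown, and "the series" means these compounds.

Working notes on the series. Compound 1 `CC#CCC(O)(c1ccc(N2CCN(S(=O)(=O)c3ccc(N)nc3)C[C@@H]2C#CC)cc1)C(F)(F)F` is the reference point; in an assay on isolated protein for inhibition of glucokinase regulatory protein (Homo sapiens), read by AlphaScreen, with stated times of 20 min and 4 h (a lower number here means a stronger inhibitor, a higher number a weaker inhibitor), compound 1 gives 5 nM, the lowest of the two numbers recorded so far. Among the measured compounds shown here, the only other measured member, compound 2 `CC#C[C@H]1CN(S(=O)(=O)c2ccc(N)nc2)CCN1c1ncc(C(C)(O)C(F)(F)F)s1`, gives 49 nM in this assay, a higher number that lies beyond the usual scatter; compound 2 also carries a different core, so its value says nothing direct about the change examined here.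

Compound 3 `CC#C[C@H]1CN(S(=O)(=O)c2ccc(N)nc2)CCN1c1ccc([C@](O)(CO)C(F)(F)F)cc1` has not yet been measured in this assay. It differs from compound 1 in one place: a group of 8 heavy atoms (3 carbon, 2 oxygen, 3 fluorine; no ring) in place of a group of 10 heavy atoms (6 carbon, 1 oxygen, 3 fluorine; no ring), on an aromatic carbon. The group that leaves carries a triple bond and a single hydroxyl; the 1,2-dihydroxy-1-(trifluoromethyl)ethyl that enters is two heavy atoms smaller and brings a second hydroxyl with a defined stereocentre.

For the measured compounds named here, no pair of measured compounds shows this change, so the expectation rests on compound 1 alone. For compound 3 a step of a 3.0-fold higher number from compound 1 to compound 3 (0.48 log units; beyond the scatter) toward a weaker inhibitor is expected, modest in size and close to the edge of the scatter. Compound 3 is estimated at 15 nM in this assay, with a likely range from 5 nM to 50 nM.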

Compound 3, half-maximal inhibitory concentration: 28 nM
For compound 3 the middle estimate is 1.9-fold (0.27 log units) below the measured one; low and high end bracket the measured number.
By their numbers in this assay, from the lowest: compound 1; then compounds 3 and 2 (each within the scatter of the next).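

Among the compounds shown here, at this position, on an aromatic carbon para to a large group, the first direct reading of a change comes from this assay: replacing the group that carries the triple bond with 1,2-dihydroxy-1-(trifluoromethyl)ethyl gives a 5.6-fold higher number from compound 1 to compound 3 (0.75 log units; beyond the scatter), a modest loss on the shared core. The position therefore accepts a group that is smaller by count of heavy atoms, has no triple bond and holds a second hydroxyl, while compound 3 stays a nanomolar inhibitor at 28 nM, although this exchange does not match compound 1. For the compounds shown here, nothing available bears on the reason for this step, and the single exchange alters the chain, the hydroxyl count and the defined stereocentre together.

The data do not separate those alterations from one another. The opposite configuration at the stereocentre has not been measured. A methyl, methoxymethyl or aminomethyl in place of the hydroxymethyl part of the entering group, or a longer chain ending in a hydroxyl, could help separate the loss of the triple bond from the gain of the second hydroxyl.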